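Swapping the Sulfoamino Pyrrolidine for Piperidine

This account rests on a few compounds, and the source may have more. Where it says the series, first, only, none or still open, it means among the compounds named here.

Compound 1, `O=C(CCc1ccc(C(F)(F)F)cc1)Nc1ccc2nc(N3CCC(NS(=O)(=O)O)C3)ccc2c1`: 50 nM in a functional assay on HEK293 cells for activation of melanin-concentrating hormone receptor 1 (Rattus norvegicus), read by inositol phosphate accumulation; a higher number here means that more compound is needed for the effect, a lower number that less compound is needed
Compound 2, `O=C(CCc1ccc(C(F)(F)F)cc1)Nc1ccc2nc(N3CC4CCC3CC4)ccc2c1`: 190 nM in this assay

Of the two numbers measured, compound 1 has the lowest; the nearest is compound 2, with a higher number beyond the scatter. Compound 3, `O=C(CCc1ccc(C(F)(F)F)cc1)Nc1ccc2nc(N3CCCCC3)ccc2c1`, differs from compound 1 by piperidin-1-yl in place of 3-(sulfoamino)pyrrolidin-1-yl on an aromatic carbon. Within the data shown here, the one measured step that bears on this, a 3.8-fold higher number from compound 1 to compound 2 (0.58 log units; beyond the scatter), also replaced the 3-(sulfoamino)pyrrolidin-1-yl group with a smaller amine and gave a modest rise. A rise of similar size is therefore expected for a 4.0-fold higher number from compound 1 to compound 3 (0.60 log units; beyond the scatter). Compound 3 is estimated at 200 nM, with a range from 60 nM to 700 nM.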

Compound 3, half-maximal effective concentration: 110 nM
Compound 3: the middle estimate sits 1.8-fold (0.26 log units) above what was measured; measured number inside the range.
By their numbers in this assay, from the lowest: compound 1; then compounds 3 and 2 (each within the scatter of the next).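

In this assay, the 3-(sulfoamino)pyrrolidin-1-yl group can give way to the plain piperidin-1-yl group on this aromatic carbon at a modest cost, with a 2.2-fold higher number from compound 1 to compound 3 (0.34 log units; beyond the scatter). The second ring of the group in compound 2 makes no difference that can be read, since a 1.7-fold lower number from compound 2 to compound 3 (0.24 log units; within the scatter). Nothing available explains either step.

The step from compound 1 to compound 3 changes ring size and substituent together, so these remain unseparated. An unsubstituted pyrrolidin-1-yl group, or a pyrrolidine bearing an amine or a carboxylic acid, would be needed to tell them apart.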